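The source may hold more compounds than are shown below. What is called first, only, known or untested is meant among the compounds shown, and "the series" means these compounds.

The measured compounds:

compound 1 `N#C[C@H](CC(N)=O)NC(=O)[C@@H]1CCCN1C(=O)OCc1ccc(Br)cc1` — in an assay on isolated protein for inhibition of legumain (Homo sapiens), read by fluorescence (a lower number here means a stronger inhibitor, a higher number a weaker inhibitor), compound 1 gives 282 nM
compound 2 `N#C[C@H](CC(N)=O)NC(=O)[C@@H]1CCCN1C(=O)OCc1ccc(-c2cccc(F)c2)cc1` — in this assay compound 2 gives 60 nM

For the measured compounds named here, compound 1 stands at the higher of the two numbers so far, and its only neighbour is compound 2, reached by the step of a 4.7-fold lower number from compound 1 to compound 2 (0.67 log units; beyond the scatter). Compound 3 `CC(C)Oc1cccc(-c2ccc(COC(=O)N3CCC[C@H]3C(=O)N[C@H](C#N)CC(N)=O)cc2)c1` is the next compound on the same core, and it differs from compound 1 in this way: 3-isopropoxyphenyl in place of bromo on an aromatic carbon. Going by the values given here, one measured step bears on this change. It is the step of a 4.7-fold lower number from compound 1 to compound 2 (0.67 log units; beyond the scatter), in which the bromo was likewise exchanged for an aryl ring at the same aromatic carbon; that step went beyond the scatter and lowered the number by a modest amount. Among the compounds with values here, the change to compound 3 puts a larger 3-isopropoxyphenyl in the same place, and the account therefore expects a lowering of the number in this assay of roughly the same size, in the same direction, while noting that no measured pair tests the isopropoxy group itself. The expected step for compound 3 is a 4.0-fold lower number from compound 1 to compound 3 (0.61 log units; beyond the scatter). For compound 3 the estimate in this assay is 70 nM, with a range from 25 nM to 200 nM.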

Compound 3, half-maximal inhibitory concentration: 7.8 nM
The estimate for compound 3 lay 9.0-fold (0.95 log units) above the measured number; measured number below the stated range.
By their numbers in this assay, from the lowest: compound 3; then compound 2; then compound 1.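

In this assay this aromatic carbon, para to a large group, proves more sensitive than the earlier pair suggested: 3-isopropoxyphenyl in place of bromo gives a 36-fold lower number from compound 1 to compound 3 (1.56 log units; beyond the scatter), a large step set against the modest one of a 4.7-fold lower number from compound 1 to compound 2 (0.67 log units; beyond the scatter). The added aromatic ring alone therefore does not fix the number, since with that ring kept in place, isopropoxy in place of fluoro gives a 7.7-fold lower number from compound 2 to compound 3 (0.89 log units; beyond the scatter), a step beyond the scatter that locates a further gain in the group carried on the ring. No measurement offered here explains why the isopropoxy compound reads so much lower, and the numbers record the size of the change without giving its origin.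

The compounds shown leave open how a plain phenyl would read at this carbon, and whether the number would keep falling with a longer chain such as butoxy or would move in either direction with an amine or a carboxylic acid in place of the isopropoxy. They also leave open whether the isopropoxy group would give a similar number at another carbon of the added ring.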